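Phenoxy substitution on the aryl ring of compound 1

The source may hold more compounds than are shown below. What is called first, only, known or untested is meant among the compounds shown, and "the series" means these compounds.

Compound 1 `C=C[C@@H]1OC(c2ccccc2)=N[C@H]1CO` anchors the series at its lower end. In an assay on isolated protein for inhibition of matrix metalloproteinase-9 (Homo sapiens) (a lower number here means a stronger inhibitor, a higher number a weaker inhibitor), compound 1 gives > 4000000 nM, which is a limit of the assay rather than a number (the limit of > 4000000 nM in this assay, at which 1 of the 2 values shown sits). Compound 2 `C=C[C@@H]1OC(c2ccc(Br)cc2)=N[C@H]1Sc1ccccc1` is the other measured member; in this assay compound 2 gives 94000 nM. Compound 3 `C=C[C@@H]1OC(c2ccc(Oc3ccccc3)cc2)=N[C@H]1CO` differs from compound 1 by phenoxy in place of hydrogen on an aromatic carbon. The step of an at least 2.6-fold lower number from compound 1 to compound 3 (0.42 log units; beyond the scatter) is expected to be a modest gain in this assay, with a fair chance that only a limit is again reported. Compound 3 is estimated at 1500000 nM in this assay, within 200000 nM to 8000000 nM.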

Compound 3, inhibition constant: 32000 nM
Compound 3: middle estimate off by 47-fold (1.67 log units), on the high side; the measured number lies below the stated range.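

Replacing hydrogen with phenoxy on the aromatic carbon para to a group of 9 heavy atoms gives an at least 120-fold lower number from compound 1 to compound 3 (2.09 log units; beyond the scatter) in this assay. For the compounds shown here, this is the first single-place change, and it shows that this position can carry an added aromatic ring with a large gain. The value of compound 1 is a limit, not a number: the limit of > 4000000 nM in this assay, at which 1 of the 3 values shown sits.

Still open, going by these compounds, is whether an amine, a carboxylic acid or a longer alkyl chain on this aromatic carbon would give a similar step. On these data alone, it is also open whether the gain rests on the ring of phenoxy or on its oxygen.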